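The compounds below may be only part of what the source reports. "The series", "measured", "known", "first", "only" and "open" are said of these compounds alone.

Measured so far:
- compound 1 `C/C(=N/NC(=S)Nc1ccc(Cl)cc1)c1ccccn1` gives 5.9 nM
- compound 2 `C/C(=N\NC(=S)Nc1ccc(F)cc1)c1ccccn1` gives 17 nM
- compound 3 `C/C(=N/NC(=S)Nc1ccc(I)cc1)c1ccccn1` gives 64 nM

In a functional assay on T98G cells (Homo sapiens) for cytotoxicity, read by MTT assay, with a stated time of 48 h (a higher number here means a weaker inhibitor, a lower number a stronger inhibitor), compound 3 stands at the highest number of the three, with compound 2 the nearest and compound 1 the furthest from it, both gaps lying beyond the scatter. Compound 4 `C/C(=N/NC(=S)Nc1ccc(F)cc1)c1ccccn1` differs from compound 3 in one place: fluoro in place of iodo on an aromatic carbon. Among the compounds with values here, one measured step bears on this change, an 11-fold higher number from compound 1 to compound 3 (1.04 log units; beyond the scatter), a large step upward when iodo entered. Taking iodo out again should therefore move the number downward by a sizeable step, and compound 2, which also carries fluoro, gives 17 nM. Compound 4 is expected to give 15 nM, in the range 5 nM to 45 nM, an estimated step of a 4.3-fold lower number from compound 3 to compound 4 (0.63 log units; beyond the scatter).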

Compound 4, half-maximal inhibitory concentration: 17 nM
Compound 4: the middle estimate sits 1.1-fold (0.05 log units) below what was measured; the range from low to high includes it.
By their numbers in this assay, from the lowest: compound 1; then compounds 2 and 4 (each within the scatter of the next); then compound 3.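

In this assay, fluoro in place of iodo on this aromatic carbon gives a 3.8-fold lower number from compound 3 to compound 4 (0.58 log units; beyond the scatter), while fluoro in place of chloro gives a 2.9-fold higher number from compound 1 to compound 4 (0.46 log units; beyond the scatter), so fluoro falls between chloro and iodo. Changing the double bond from E to Z as drawn gives no change at the digits printed from compound 2 to compound 4 (within the scatter), and this comparison rests on a single point: the fact that compounds 2 and 4 differ only in the configuration as drawn. The compounds shown leave open whether a non-halogen group at this place, such as an amine or a methoxy group, would give a number below that of compound 1. They also leave open how any change elsewhere on the shared core would act.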